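The compounds below may be only part of what the source reports. "The series", "measured", "known", "first", "only" and "open" are said of these compounds alone.

Among the measured compounds shown here, in an ADME assay on the whole organism (Macaca fascicularis) for metabolic stability, read by LC-MS, using cassette dosing, at a dose of 1 mg/kg by the oral route (on this read-out lower numbers stand for a shorter-lived compound and higher numbers for a longer-lived compound), compound 2 `CCCCN(c1nc2c(CO)cccc2o1)[C@H](C)c1ccc(-c2ccccc2-c2nnn[nH]2)cc1` gives 1.6 h, the lowest of the two numbers measured so far. Compound 1 `CCCCN(c1nc2c(C(=O)O)cccc2o1)[C@H](C)c1ccc(-c2ccccc2-c2nnn[nH]2)cc1` gives 3.7 h. For the measured compounds named here, the only measured step, a 2.3-fold lower number from compound 1 to compound 2 (0.36 log units; beyond the scatter), is modest in size. Compound 3 `CCCCN(c1nc2c(C(=O)NS(C)(=O)=O)cccc2o1)[C@H](C)c1ccc(-c2ccccc2-c2nnn[nH]2)cc1` carries a further change at the same position: (methylsulfonyl)carbamoyl in place of hydroxymethyl on an aromatic carbon. Going by the values given here, no measured step covers this exact exchange, so the size of the earlier step is the only guide, and its direction cannot be read across. A modest shift is therefore expected for compound 3, estimated as a 1.9-fold higher number from compound 2 to compound 3 (0.27 log units; within the scatter), giving an expected 3 h with a range from 1.3 h to 7 h.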

Compound 3, half-life: 2.7 h
The estimate for compound 3 lay 1.1-fold (0.05 log units) above the measured number, within the range that was stated.
By their numbers in this assay, from the lowest: compounds 2, 3 and 1 (each within the scatter of the next, the first and the last beyond it).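

In this assay, the (methylsulfonyl)carbamoyl group at this position cannot be told apart from either earlier group. Exchanging hydroxymethyl for it gives a 1.7-fold higher number from compound 2 to compound 3 (0.23 log units; within the scatter), and putting methanesulfonamido in place of hydroxy on the carbonyl carbon gives a 1.4-fold lower number from compound 1 to compound 3 (0.14 log units; within the scatter). Nothing available explains these numbers. Still open is whether a plain primary amide or an amine at this position, or an ethyl or longer chain in place of the methyl on the sulfonyl, would also stay within the scatter of these compounds.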